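Benzyl swap on a sterically hindered phenol amide

A few compounds are considered here, and "the series" means these few. Any claim that something is new, unique, unknown or untested is made for them only; others in the source may bear on it.

Compound 1 `CC(C)(C)c1cc(C(=O)NCCC2CCN(Cc3ccccc3)CC2)cc(C(C)(C)C)c1O` in an assay on isolated protein for inhibition of Amine oxidase [flavin-containing] A (Homo sapiens), read by fluorescence, with stated times of 15 min and 20 min (a higher number here means a weaker inhibitor, a lower number a stronger inhibitor), gives 109000 nM. Compound 2 `CC(C)(C)c1cc(/C=C/C(=O)NCCC2CCN(Cc3ccccc3F)CC2)cc(C(C)(C)C)c1O` in this assay gives 60200 nM.

Compound 2 and compound 1 return numbers that lie within the usual scatter of each other, so neither can be set apart from the other on these two readings. Compound 3 `CC(C)(C)c1cc(/C=C/C(=O)NCCC2CCN(Cc3cccc(Cl)c3)CC2)cc(C(C)(C)C)c1O` has not been measured. It differs from compound 2 in one place: 3-chlorophenyl in place of 2-fluorophenyl on a saturated chain carbon bound to an amine nitrogen in a ring. Among the compounds with values here, no measured pair in this set shows what such a change on the benzyl group does, so nothing here points to a step beyond the scatter in either direction. The expected step from compound 2 to compound 3 in this assay is therefore a 1.1-fold lower number from compound 2 to compound 3 (0.04 log units; within the scatter), essentially none beyond the scatter. Compound 3 is accordingly estimated to give 55000 nM in this assay, with a plausible range from 20000 nM to 150000 nM.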

Compound 3, half-maximal inhibitory concentration: 65100 nM
Compound 3: the middle estimate sits 1.2-fold (0.07 log units) below what was measured; low and high end bracket the measured number.
By their numbers in this assay, from the lowest: compounds 2, 3 and 1 (each within the scatter of the next).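

Within the data shown here, the change from 2-fluorobenzyl to 3-chlorobenzyl gives the first direct reading at this position, on a saturated chain carbon bound to an amine nitrogen in a ring. In this assay it amounts to a 1.1-fold higher number from compound 2 to compound 3 (0.03 log units; within the scatter), so this exchange of one substituted phenyl for another does not set the two compounds apart. No supporting measurement bears on this result.

Still open, going by these compounds, is whether a methoxybenzyl, a pyridylmethyl or a cyclohexylmethyl group at the same place on the shared core would move the number beyond the scatter. This single pair also changes the halogen and its place on the phenyl ring together, so it cannot show what either change does alone.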